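A few compounds are considered here, and "the series" means these few. Any claim that something is new, unique, unknown or untested is made for them only; others in the source may bear on it.

Working notes on the series. Compound 1 `O=C(CCCc1cn(S(=O)(=O)c2cccs2)c2ccccc12)NCCCn1ccnc1` in an assay on isolated protein for activation of Insulin-degrading enzyme (Homo sapiens), read by fluorescence, with stated times of 10 min and 20 min (on this read-out higher numbers stand for an effect only at larger amounts of compound and lower numbers for an effect already at smaller amounts), gives 5500 nM; 5010 nM (2 entries) (the several entries of compound 1 in this assay, 5500 nM; 5010 nM (2 entries)). Among the compounds with values here, compound 2 `O=C(CCCc1cn(S(=O)(=O)c2ccccc2)c2ccccc12)NCCCn1ccnc1` in this assay gives 13200 nM, the only number recorded for it there; a further entry gives no single number. Compound 3 `O=C(CCCc1cn(S(=O)(=O)c2ccc(F)cc2)c2ccccc12)NCCCn1ccnc1` is not yet measured in this assay. Its difference from compound 2 is fluoro in place of hydrogen on an aromatic carbon. Within the data shown here, no measured step of this kind exists, so no direction beyond the scatter is expected, and the expected step is a 1.3-fold lower number from compound 2 to compound 3 (0.12 log units; within the scatter). Compound 3 is estimated at 10000 nM in this assay, within 4000 nM to 25000 nM.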

Compound 3, half-maximal effective concentration: 6760 nM
Beside the measured number, compound 3's estimate is 1.5-fold (0.17 log units) above it; the measured number falls inside the stated range.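

In this assay, within the data shown here, the change from phenyl to 4-fluorophenyl gives a 2.0-fold lower number from compound 2 to compound 3 (0.29 log units; within the scatter), the first reading at this position, para to a large group. A single fluoro here therefore leaves the number within the scatter, so this change shows no clear effect. Repeat entries give a gauge of agreement within the series: the several entries of compound 1 in this assay, 5500 nM; 5010 nM (2 entries)

Still open, on these data alone, is whether a larger or charged group at this position, such as trifluoromethyl, an amine or a carboxylic acid, would move the number beyond the scatter. As far as these compounds go, the effect of fluoro elsewhere on the six-membered ring also remains open.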